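From urea to carbamate on the shared core

The compounds below may be only part of what the source reports. "The series", "measured", "known", "first", "only" and "open" are said of these compounds alone.

Measured compounds:
- compound 1, `CCNC(=O)Nc1cccc2c1CN(C)CC2c1ccccc1`, in a functional assay on the whole organism for inhibition of sodium-dependent dopamine transporter (Mus musculus); a lower number here means that less compound is needed, a higher number that more compound is needed for the effect: > 80 mg/kg
- compound 2, `CCCNC(=O)Nc1cccc2c1CN(C)CC2c1ccccc1`, in this assay: > 120 mg/kg
- compound 3, `CCCCNC(=O)Nc1cccc2c1CN(C)CC2c1ccccc1`, in this assay: 69 mg/kg

The values of compound 1 and compound 2 are limits of this assay, not numbers. For compound 1 the value > 80 mg/kg is such a limit. For compound 2 the value > 120 mg/kg is likewise only a limit. Within the data shown here, compound 3 is therefore the only compound of the three with a real number in this assay, and the two others sit at limits.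

Compound 4, `CCOC(=O)Nc1cccc2c1CN(C)CC2c1ccccc1`, has not been measured. It differs from compound 3 in one place: ethoxy in place of butylamino on a carbonyl carbon.

The measured steps all concern the length of the chain on the urea: an at least 1.1-fold lower number from compound 1 to compound 3 (0.06 log units; that floor lies within the scatter), an at least 1.7-fold lower number from compound 2 to compound 3 (0.24 log units; that floor lies within the scatter), while a step that the two limits leave unreadable from compound 1 to compound 2. None of them changes the urea itself, so none bears directly on the step to compound 4. What they show is that shorter chains on that side end at limits (the limit of > 120 mg/kg in this assay, at which 1 of the 3 values shown sits, (the limit of > 80 mg/kg in this assay, at which 1 of the 3 values shown sits)), and ethoxy is shorter than butylamino. The step of a 1.7-fold higher number from compound 3 to compound 4 (0.24 log units; within the scatter) is therefore expected to run toward a higher number, and may well end at a limit again. For compound 4 the estimated value in this assay is 120 mg/kg, within the range 50 mg/kg to 300 mg/kg.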

Compound 4, dose for half-maximal effect: 2.5 mg/kg
For compound 4 the middle estimate is 48-fold (1.68 log units) above the measured one; the whole stated range lies above it.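

Swapping the group on the carbonyl carbon does far more in this assay than any readable step in chain length on the urea: ethoxy in place of butylamino gives a 28-fold lower number from compound 3 to compound 4 (1.44 log units; beyond the scatter), and ethoxy in place of propylamino gives an at least 48-fold lower number from compound 2 to compound 4 (1.68 log units; beyond the scatter). Chain length alone cannot account for the gain, since ethoxy and ethylamino carry the same ethyl chain, yet that swap gives an at least 32-fold lower number from compound 1 to compound 4 (1.50 log units; beyond the scatter). Compound 1 stands only at a limit, as does compound 2, so the steps from these two compounds are floors: the limit of > 80 mg/kg in this assay, at which 1 of the 4 values shown sits.

Nothing shown gives a measured property that explains the size of this change. As far as these compounds go, how a butoxy group or a longer chain on the carbamate oxygen would behave also stays open.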